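The source may hold more compounds than are shown below. What is called first, only, known or untested is meant among the compounds shown, and "the series" means these compounds.

Measured so far in a functional assay on XF498 cells (Homo sapiens) for cytotoxicity; on this read-out lower numbers stand for stronger inhibition and higher numbers for weaker inhibition:
- compound 1 `Cc1ccc(-c2cc3cc(C)ccc3c(O)n2)cc1`: 11200 nM
- compound 2 `Cc1ccc2c(N3CCN(C)CC3)nc(-c3ccc(Cl)cc3)cc2c1`: 4070 nM

Compound 2, at 4070 nM, holds the lower of the two numbers in this assay. Compound 1, at 11200 nM, stands higher, and the gap lies beyond the scatter. With only these two values, no trend can be claimed for the series.

Next in line is compound 3 `Cc1ccc(-c2cc3cc(C)ccc3c(N3CCN(C)CC3)n2)cc1`, which departs from compound 2 in one place: methyl in place of chloro on an aromatic carbon. This is methyl in place of chloro on an aromatic carbon, para to a large group, so that 4-chlorophenyl becomes 4-methylphenyl. All else stays as in compound 2.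

Going by the values given here, no measured pair isolates this change, so the data do not show its size directly. The change is a single-atom swap, and no step beyond the scatter is expected in this assay, with at most a slight drift toward a higher number. The expected step of a 1.2-fold higher number from compound 2 to compound 3 (0.09 log units; within the scatter) stays within the scatter. For compound 3 the estimated value is 5000 nM, with an expected range of 2000 nM to 12000 nM.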

Compound 3, half-maximal inhibitory concentration: 4470 nM
Estimate against measurement, compound 3: 1.1-fold (0.05 log units) above; low and high end bracket the measured number.
By their numbers in this assay, from the lowest: compounds 2 and 3 (each within the scatter of the next); then compound 1.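

In this assay, going by these compounds alone, the swap of 4-chlorophenyl for 4-methylphenyl (a 1.1-fold higher number from compound 2 to compound 3 (0.04 log units; within the scatter)) gives the first direct reading at this place on the six-membered aromatic ring of carbon only, and this read-out does not separate chloro from methyl there. Within the data shown here, compound 3 also forms a single-place pair with compound 1, and 4-methylpiperazin-1-yl in place of hydroxy on an aromatic carbon (a 2.5-fold lower number from compound 1 to compound 3 (0.40 log units; beyond the scatter)) gives the only step so far that lies beyond the scatter, though it is modest in size. Nothing at hand accounts for the size of either step, so both stand here as observations only.

Only chloro and methyl are shown at the first place, so it stays open whether a methoxy group, a carboxylic acid or a longer alkyl chain on the same aromatic carbon would move the number beyond the scatter. At the second place, the series shows only hydroxy and 4-methylpiperazin-1-yl, which leaves open whether the step would hold with another amine, such as morpholin-4-yl or an unsubstituted piperazine.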